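This account rests on a few compounds, and the source may have more. Where it says the series, first, only, none or still open, it means among the compounds named here.

Among the compounds with values here, in a physicochemical assay for lipophilicity, at pH 7.4 (a higher number here means a more lipophilic compound, a lower number a more polar compound), compound 1 `CCc1ccc(N(CC(C)C)S(=O)(=O)c2ccc3c(c2)C(O)CC(C2CCOCC2)O3)cc1` gives 4.12 as the highest of the three numbers measured so far. Compound 2 `CC(C)CN(c1ccccc1F)S(=O)(=O)c1ccc2c(c1)C(O)CC(C1CCOCC1)O2` stands at 3.39 in the middle and compound 3 `CCc1ccc(N(CC(C)C)S(=O)(=O)c2ccc3c(c2)C(O)CC(C2CCNCC2)O3)cc1` stands at 1.04 at the low end. Compound 4 `CCc1ccc(N(CC(C)C)S(=O)(=O)c2ccc3c(c2)C(O)C[C@H](C2CCOCC2)O3)cc1` is still unmeasured. Its difference from compound 1 is the two compounds have the same atoms and bonds; at least one stereo element is drawn with a configuration in one of them and without one in the other: 1 of 2 stereo elements differ; a stereocentre at a saturated ring carbon is drawn without a configuration in compound 1 and R in compound 4 and it means that a stereocentre at a saturated ring carbon is drawn without a configuration in compound 1 and R in compound 4. Both measured steps exchange a group. One gives a number 0.73 log units lower from compound 1 to compound 2 (beyond the scatter) with 2-fluorophenyl in place of 4-ethylphenyl on a sulfonamide nitrogen. The other gives a number 3.08 log units lower from compound 1 to compound 3 (beyond the scatter) with piperidin-4-yl in place of oxan-4-yl on a saturated ring carbon. Within the data shown here, neither step, modest or large, measures a change of drawn configuration alone, and no measured pair shows one. No step beyond the scatter is therefore expected in this assay for this change. The expectation starts from compound 1 at 4.12 as the anchor. The estimated outcome is a number 0.02 log units lower from compound 1 to compound 4 (within the scatter) as the expected step. For compound 4 the expected value is 4.1 with an estimated range from 3.8 to 4.4 as the likely span.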

Compound 4, distribution coefficient: 4.12
Compound 4: the middle estimate sits 0.02 log units below what was measured, within the range that was stated.
By their numbers in this assay, from the lowest: compound 3; then compound 2; then compounds 1 and 4 (each within the scatter of the next).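

In this assay, drawing the saturated ring carbon as R rather than without a configuration gives no change at the digits printed from compound 1 to compound 4 (within the scatter). Within the data shown here, the earlier steps each exchanged a group, including the one at this same carbon, a number 3.08 log units lower from compound 1 to compound 3 (beyond the scatter), whereas this is the first pair with identical atoms and bonds. It therefore offers the first reading at this position with no group exchanged, and the only difference between the two compounds is one of drawn stereochemistry: the fact that one of compounds 1 and 4 is drawn with a defined configuration and the other without, at the place where they differ

The compounds shown include no S form at this carbon, and the second stereo element is not defined by this pair. On these data alone, whether the R configuration would give the same reading with a different group on this carbon, such as piperidin-4-yl or a carboxylic acid, remains open.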